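Pyridin-2-yl for Isopropyl at a Ring Nitrogen

The compounds below may be only part of what the source reports. "The series", "measured", "known", "first", "only" and "open" are said of these compounds alone.

Compound 1 `CN(C[C@H]1Cc2c(cccc2N2CCNC(C)(C)C2)CN1)[C@H]1CCCc2cccnc21`: in a functional assay on CCRF-CEM cells for agonist activity at C-X-C chemokine receptor type 4 (Homo sapiens), read by calcium flux, with a stated time of 25 min (on this read-out higher numbers stand for an effect only at larger amounts of compound and lower numbers for an effect already at smaller amounts), compound 1 gives > 30000 nM, a limit of the assay.
Compound 2 `CC(C)N1CCN(c2cccc3c2C[C@H](CN(C)[C@H]2CCCc4cccnc42)NC3)CC1`: in this assay compound 2 gives > 30000 nM, also a limit.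
Compound 3 `CN(C[C@H]1Cc2c(cccc2N2CCN3CCC[C@H]3C2)CN1)[C@H]1CCCc2cccnc21`: in this assay compound 3 gives > 30000 nM, again a limit.

Compound 2 thus stands only at a limit, like every other value shown (the limit of > 30000 nM in this assay, at which 3 of the 3 values shown sit). The steps a step that the two limits leave unreadable from compound 1 to compound 2, a step that the two limits leave unreadable from compound 1 to compound 3 and a step that the two limits leave unreadable from compound 2 to compound 3 cannot be sized because all three values sit at the same limit (the limit of > 30000 nM in this assay, at which 3 of the 3 values shown sit).

Compound 4 `CN(C[C@H]1Cc2c(cccc2N2CCN(c3ccccn3)CC2)CN1)[C@H]1CCCc2cccnc21` differs from compound 2 by pyridin-2-yl in place of isopropyl on an amine nitrogen in a ring. Among the measured compounds shown here, no measured step covers this change, and the limits give no direction. Compound 4 is therefore expected to remain near the limit, estimated at 40000 nM with a range from 6000 nM to 300000 nM. The expected step that the limit leaves unreadable from compound 2 to compound 4 is accordingly small, and a limit rather than a number is the likeliest outcome.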

Compound 4, half-maximal effective concentration: > 30000 nM
Compound 4: no number, only a limit; the forecaster's own chance of this, stated with the estimate: 75%; the middle value lies beyond the limit too.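

Compound 4 sits at a limit, as compound 2 does, so no step between them can be read: the limit of > 30000 nM in this assay, at which 4 of the 4 values shown sit.

The compounds shown leave open whether any group on this ring nitrogen gives a measurable value in this assay.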